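Two-triazole series: chloro to methoxy on the aryl ring

A few compounds are considered here, and "the series" means these few. Any claim that something is new, unique, unknown or untested is made for them only; others in the source may bear on it.

Within the shared core, compound 2 `Sc1nnc(Sc2nnc(-c3ccccc3)n2-c2ccccc2)n1-c1ccccc1` gives 28300 nM in a functional assay on HT-29 cells (Homo sapiens) for inhibition, read by MTT assay, with a stated time of 48 h; a lower number here means a stronger inhibitor, a higher number a weaker inhibitor. Compound 3 `Sc1nnc(CSc2nnc(-c3ccccc3)n2-c2ccccc2)n1-c1ccc(Cl)cc1` gives 36600 nM in this assay, the highest of the two numbers in hand; its gap to compound 2 lies within the scatter, so no order between the two can be claimed. For compound 1 `CCOc1ccc(-n2c(S)nnc2CSc2nnc(-c3ccccc3)n2-c2ccccc2)cc1` this assay holds "not determined" (no result reported), so no number is available. Among the compounds with values here, compound 4 `COc1ccc(-n2c(S)nnc2CSc2nnc(-c3ccccc3)n2-c2ccccc2)cc1` differs from compound 3 by methoxy in place of chloro on an aromatic carbon; no measured pair shows this change. For compound 4 the step of a 1.1-fold lower number from compound 3 to compound 4 (0.04 log units; within the scatter) is expected to remain within the scatter, with no firm direction. The estimate for compound 4 in this assay is 33000 nM, with a range from 12000 nM to 95000 nM.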

Compound 4, half-maximal inhibitory concentration: 27700 nM
Beside the measured number, compound 4's estimate is 1.2-fold (0.08 log units) above it, and the stated range covers the measured number.
By their numbers in this assay, from the lowest: compounds 4, 2 and 3 (each within the scatter of the next).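

Methoxy in place of chloro on an aromatic carbon, para to a large group, gives in this assay a 1.3-fold lower number from compound 3 to compound 4 (0.12 log units; within the scatter) and provides the first measured pair for this change. This position therefore accepts a group carrying a hydrogen-bond acceptor, which chloro lacks, with no order between the two compounds to be claimed. Nothing at hand accounts for this result.

Still open, as far as these compounds go, is whether an amine or a carboxylic acid at this position would move the number beyond the scatter. A longer alkoxy chain poses the same question.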